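Sulfamoyl urea series: step from compound 2 to compound 4

The source may hold more compounds than are shown below. What is called first, only, known or untested is meant among the compounds shown, and "the series" means these compounds.

Measured in an assay on liver for inhibition of sterol O-acyltransferase 1 (Rattus norvegicus), using microsomes; a higher number here means a weaker inhibitor, a lower number a stronger inhibitor:
compound 1, `CC(C)c1cccc(C(C)C)c1NC(=O)NS(=O)(=O)N(C)C`: 3900 nM
compound 2, `CC(C)NS(=O)(=O)NC(=O)Nc1c(C(C)C)cccc1C(C)C`: 18000 nM
compound 3, `CC(C)c1cccc(C(C)C)c1NC(=O)NS(=O)(=O)N1CCCC1`: 15000 nM

Compound 2 shows the highest number of the three in this assay; its nearest neighbour is compound 3, within the scatter, and the one furthest from it is compound 1, beyond the scatter.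

Compound 4, `CC(C)CN(CC(C)C)S(=O)(=O)NC(=O)Nc1c(C(C)C)cccc1C(C)C`, has not been measured. It differs from compound 2 in one place: diisobutylamino in place of isopropylamino on a sulfonyl sulfur.

Within the data shown here, no measured step exchanges one dialkylamino group for a larger one on the sulfonyl sulfur, so nothing bears directly on this change. What is known: a 4.6-fold higher number from compound 1 to compound 2 (0.66 log units; beyond the scatter), a 3.8-fold higher number from compound 1 to compound 3 (0.59 log units; beyond the scatter) and a 1.2-fold lower number from compound 2 to compound 3 (0.08 log units; within the scatter). Among the measured compounds shown here, the only compound with a dimethylamino on the sulfonyl sulfur, compound 1, gives the lowest number, while isopropylamino and pyrrolidin-1-yl give numbers within the scatter of each other. A step of modest size or none beyond the scatter is therefore expected in this assay, with the direction uncertain. Compound 4 is estimated at 10000 nM in this assay, range 2500 nM to 40000 nM, which means an expected 1.8-fold lower number from compound 2 to compound 4 (0.26 log units; within the scatter).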

Compound 4, half-maximal inhibitory concentration: 420 nM
For compound 4 the middle estimate is 24-fold (1.38 log units) above the measured one; the whole stated range lies above it.
By their numbers in this assay, from the lowest: compound 4; then compound 1; then compounds 3 and 2 (each within the scatter of the next).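

In this assay, among these compounds, the group on the sulfonyl sulfur proves able to move the number much further than the earlier compounds showed: diisobutylamino gives a 43-fold lower number from compound 2 to compound 4 (1.63 log units; beyond the scatter) and a 36-fold lower number from compound 3 to compound 4 (1.55 log units; beyond the scatter), both large steps where the earlier ones were modest at most. It also gives a 9.3-fold lower number from compound 1 to compound 4 (0.97 log units; beyond the scatter), so compound 4 now has the lowest number of the four, and the number does not follow group size in one direction: compound 1, with dimethylamino, has a lower number than compounds 2 and 3, yet compound 4, with the larger diisobutylamino, lies lower still. Nothing in the data shown accounts for this step.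

As far as these compounds go, it remains open whether the step needs both isobutyl chains, which isobutylamino, keeping the hydrogen on the nitrogen and carrying a single chain, would test. Di-n-butylamino and dibenzylamino would show whether unbranched chains or phenyl-bearing groups on the same nitrogen give a number like that of compound 4, or whether the result is specific to diisobutylamino.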